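Clearance notes on the aryl sulfone series, compound 4

The source may report more compounds than this note shows. Statements on the series, on what has been measured and on what is new or still open speak of the compounds shown alone.

Three members of the series have numbers in an ADME assay on microsomes from liver (Homo sapiens) for metabolic stability, tested at 2.5 uM; on this read-out higher numbers stand for fast clearance and lower numbers for slow clearance. Compound 1 `O=S(=O)(c1ccc(F)c(Cl)c1)c1cnc2cc(F)ccc2c1-c1cccc(F)c1` gives 0.25 mL/min, compound 2 `COc1cccc(S(=O)(=O)c2cnc3cc(F)ccc3c2-c2cccc(F)c2)c1` gives 3.36 mL/min, and compound 3 `COc1ccc(-c2c(S(=O)(=O)c3cccc(F)c3)cnc3cc(F)ccc23)cc1` gives 1.89 mL/min. Within this set compound 3 stands second highest; its nearest neighbour is compound 2, whose number lies within the scatter of it, while compound 1 lies well below it, beyond the scatter. Within the data shown here, the single step measured between two compounds differing in one place is a 13-fold higher number from compound 1 to compound 2 (1.13 log units; beyond the scatter), a change on the sulfonyl sulfur.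

Compound 4 `O=S(=O)(c1cccc(F)c1)c1cnc2cc(F)ccc2c1-c1cccc(F)c1` is not yet measured. It differs from compound 3 as follows: 3-fluorophenyl in place of 4-methoxyphenyl on an aromatic carbon. Among the measured compounds shown here, this change sits on the aromatic carbon of the shared core, not on the sulfonyl sulfur, so no measured step addresses the same position; compound 1 and compound 2 both already carry the 3-fluorophenyl that enters here, and their values differ only through the sulfonyl group. For the measured compounds named here, the one step measured is therefore only indirect evidence, showing that the sulfonyl aryl alone can move this assay strongly, but saying nothing about the carbon-bound aryl. For compound 4 a step of a 1.5-fold lower number from compound 3 to compound 4 (0.16 log units; within the scatter) is expected, i.e. no change beyond the scatter. Compound 4 is estimated at 1.3 mL/min, within a range of 0.4 mL/min to 3.5 mL/min.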

Compound 4, intrinsic clearance in a liver preparation (reported as CLH), per the amount of preparation that the assay uses: 0.24 mL/min
For compound 4 the middle estimate is 5.4-fold (0.73 log units) above the measured one; measured number below the stated range.
By their numbers in this assay, from the lowest: compounds 4 and 1 (each within the scatter of the next); then compounds 3 and 2 (each within the scatter of the next).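

In this assay, among these compounds, this position on the shared core proves able to move the number on its own: with 3-fluorophenyl in place of 4-methoxyphenyl on an aromatic carbon opposite the ring nitrogen, the result is a 7.9-fold lower number from compound 3 to compound 4 (0.90 log units; beyond the scatter), so the sulfonyl aryl is no longer the only site with a step beyond the scatter. Among these four compounds the two higher numbers belong to the two that carry methoxy, with no exception: fluoro in place of methoxy on the sulfonyl aryl gives a 14-fold lower number from compound 2 to compound 4 (1.15 log units; beyond the scatter), while replacing 3-chloro-4-fluorophenyl with 3-fluorophenyl on the sulfonyl sulfur gives only a 1.0-fold lower number from compound 1 to compound 4 (0.02 log units; within the scatter), so that change does not register here. Nothing measured in this set gives a reason for these steps.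

Each methoxy step also brings in fluoro, so the compounds shown do not separate the loss of methoxy from the gain of fluoro on either aryl. On these data alone, how a plain phenyl, a morpholine or a carboxylic acid on the carbon-bound aryl would read in this assay remains open.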